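This account rests on a few compounds, and the source may have more. Where it says the series, first, only, none or still open, it means among the compounds named here.

Measured compounds:
compound 1 `CCCc1nc(-c2ccccc2)c(CNCCCN2CCN(c3cccc(Cl)c3)CC2)o1`, 1750 nM
compound 2 `CCCc1nc(-c2ccccc2)c(CNCCCN2CCN(c3ccc(C(F)(F)F)cc3)CC2)o1`, 7250 nM
compound 3 `CCCc1nc(-c2ccccc2)c(CNCCCN2CCN(c3cccc(C)c3C)CC2)o1`, 1780 nM

In an assay on HEK293 cells for inhibition of Voltage-dependent T-type calcium channel subunit alpha-1G (Homo sapiens), read by patch clamp (a lower number here means a stronger inhibitor, a higher number a weaker inhibitor), compound 3 stands second highest of the three numbers; it sits at the same level as compound 1, the two differing only a 1.0-fold higher number from compound 1 to compound 3 (0.01 log units; within the scatter), while compound 2 lies a 4.1-fold lower number from compound 2 to compound 3 (0.61 log units; beyond the scatter) away. Compound 4 `CCCc1nc(-c2ccccc2)c(CNCCCN2CCN(c3ccc(C)cc3)CC2)o1` differs from compound 3 in one place: 4-methylphenyl in place of 2,3-dimethylphenyl on an amine nitrogen in a ring.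

Within the data shown here, two steps bear on this change. The exchange of 3-chlorophenyl for 2,3-dimethylphenyl left the number unchanged, a 1.0-fold higher number from compound 1 to compound 3 (0.01 log units; within the scatter). Among the measured compounds shown here, the exchange of 4-(trifluoromethyl)phenyl for 2,3-dimethylphenyl gave a 4.1-fold lower number from compound 2 to compound 3 (0.61 log units; beyond the scatter), so the one aryl group bearing a single substituent, 4-(trifluoromethyl)phenyl, gave the highest number of the set. For the measured compounds named here, compound 4 carries 4-methylphenyl, likewise a group with a single substituent, though with methyl rather than trifluoromethyl, and no measured compound shows how that group behaves. The expectation is therefore a step of a 2.0-fold higher number from compound 3 to compound 4 (0.29 log units; within the scatter) in this assay, of uncertain size.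

Compound 4 is estimated at 3500 nM, within 1200 nM to 10000 nM.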

Compound 4, half-maximal inhibitory concentration: 130000 nM
Estimate against measurement, compound 4: 37-fold (1.57 log units) below; measured number above the stated range.
By their numbers in this assay, from the lowest: compounds 1 and 3 (each within the scatter of the next); then compound 2; then compound 4.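

In this assay, the aryl group on the amine nitrogen in a ring proved far more sensitive than the first three compounds showed: 4-methylphenyl in place of 2,3-dimethylphenyl gave a 73-fold higher number from compound 3 to compound 4 (1.86 log units; beyond the scatter), and in place of 3-chlorophenyl it gave a 74-fold higher number from compound 1 to compound 4 (1.87 log units; beyond the scatter). Methyl in place of trifluoromethyl on an aromatic carbon gave an 18-fold higher number from compound 2 to compound 4 (1.25 log units; beyond the scatter), so among these compounds a single substituent does not fix the number, and compound 4, not compound 2, is now the weakest inhibitor. No evidence at hand accounts for these steps.

The compounds shown leave open whether unsubstituted phenyl, 3-methylphenyl or 2-methylphenyl would stay near compound 1 and compound 3 or fall toward compound 4. They also leave open whether 4-chlorophenyl would follow compound 2 or compound 4.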